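A Bromo Analogue Expected to Match Its Ethyl Parent

A few compounds are considered here, and "the series" means these few. Any claim that something is new, unique, unknown or untested is made for them only; others in the source may bear on it.

Of the compounds shown here, three have been measured in an assay for inhibition of protein kinase C iota type (Homo sapiens), read by mobility shift assay, with a stated time of 60 min; on this read-out lower numbers stand for stronger inhibition and higher numbers for weaker inhibition. Compound 3 `CCc1cc(NC(=O)c2nccnc2N)ccn1` gives 19600 nM and holds the lowest of the two numbers shown. Its nearest neighbour is compound 1 `Nc1ncccc1C(=O)Nc1ccncc1`, which in this assay gives 22000 nM, a figure within the scatter of the value of compound 3, so no order can be read between the two. Compound 2 `Nc1nccnc1C(=O)NCc1ccncc1` is a separate case: in this assay compound 2 gives > 384000 nM, and this is a limit of the assay rather than a number (the limit of > 384000 nM in this assay, at which 1 of the 3 values shown sits).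

Compound 4 `Nc1nccnc1C(=O)Nc1ccnc(Br)c1` has not yet been measured. It differs from compound 3 by bromo in place of ethyl on an aromatic carbon. Going by the values given here, no pair of measured compounds covers this change on its own. The expected step from compound 3 to compound 4 is a 1.0-fold higher number from compound 3 to compound 4 (0.01 log units; within the scatter), none beyond the scatter, since the two numbers shown so far sit close together regardless of substitution. Compound 4 is therefore expected to give about 20000 nM in this assay, within a range from 8000 nM to 50000 nM.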

Compound 4, half-maximal inhibitory concentration: > 384000 nM
Compound 4 ended at the assay's limit; the forecaster's own chance of this, stated with the estimate: 5%; middle value at least 19-fold (1.28 log units) from the limit.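

In this assay, the position on an aromatic carbon next to the ring nitrogen proves sensitive to the group it carries: bromo in place of ethyl gives an at least 19-fold higher number from compound 3 to compound 4 (1.29 log units; beyond the scatter). Until now, no pair of measured compounds covered a change at this place, and the two numbers shown sat close together. The reading of compound 4 is a limit of the assay and not a number, so the step has a lower bound only, and compound 4 joins compound 2 at that limit: the limit of > 384000 nM in this assay, at which 2 of the 4 values shown sit.

The compounds shown leave open whether this loss belongs to bromo alone or to any replacement of ethyl here; a methyl, a chlorine or a methoxy group at this position could separate the two. How far compound 4 truly lies from compound 3 also cannot be read.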